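A few compounds are considered here, and "the series" means these few. Any claim that something is new, unique, unknown or untested is made for them only; others in the source may bear on it.

Measured to date in a functional assay on NCI-H226 cells (Homo sapiens) for cytotoxicity, read by sulforhodamine B assay, with a stated time of 48 h; on this read-out higher numbers stand for weaker inhibition of growth and lower numbers for stronger inhibition of growth:

- compound 1 `ClCc1ccccc1Cn1cnc2c(Cl)nc(Cl)nc21`: 1730 nM
- compound 2 `ClCc1ccccc1Cn1cnc2ncnc(Cl)c21`: 3380 nM
- compound 3 `ClCc1ccc(Cn2cnc3c(Cl)nc(Cl)nc32)cc1`: 3550 nM

Compound 1 gives the lowest of the three numbers in this assay. Compound 2, which differs in its core, sits within the scatter of compound 1, so nothing separates the two. Compound 3, carrying the chloromethyl-substituted benzyl group on the other position of the phenyl ring, lies a little beyond the scatter above compound 1, and this is the only gap among the three that counts as real.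

Compound 4 `Nc1nc(Cl)c2ncn(Cc3ccccc3CCl)c2n1` is the next compound of the series. Relative to compound 1 the change is amino in place of chloro on an aromatic carbon. Among the compounds with values here, no pair among the measured compounds shows this exchange, so there is no measured step to lean on; what is known is only that the other modifications seen so far have moved the numbers by small amounts. The expectation for this exchange is a modest rise in the number, that is a somewhat weaker inhibition of growth, of a size that may just exceed the scatter. For compound 4 the expected step is a 2.0-fold higher number from compound 1 to compound 4 (0.31 log units; beyond the scatter). Compound 4 is accordingly estimated at 3500 nM, with a range from 1200 nM to 10000 nM.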

Compound 4, concentration for 50% growth inhibition: 2630 nM
Estimate against measurement, compound 4: 1.3-fold (0.12 log units) above, and the stated range covers the measured number.
By their numbers in this assay, from the lowest: compounds 1, 4, 2 and 3 (each within the scatter of the next, the first and the last beyond it).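

In this assay, amino in place of chloro on the aromatic carbon between two ring nitrogen atoms gives a 1.5-fold higher number from compound 1 to compound 4 (0.18 log units; within the scatter) and so does not separate the two compounds. Within the data shown here, this is the first reading of a single-place change, and it shows that this carbon can carry amino instead of chloro with no measurable difference in growth inhibition, even though the exchange adds a hydrogen-bond donor and acceptor that chloro lacks. The chloro group meta to this carbon and the 2-chloromethyl-substituted benzyl group stay the same in compound 1 and compound 4, so the reading applies to this carbon alone, and nothing available explains the outcome.

On these data alone, whether a bulkier amine such as dimethylamino, or a methoxy or hydroxyl group, on this carbon would also stay within the scatter of compound 1 remains open. Also open, as far as these compounds go, is whether the same exchange would read alike with the benzyl group of compound 3, since one pair, compound 1 and compound 4, is all that carries this change so far.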